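Compound 3 to compound 4: amino in place of bromo

The compounds below may be only part of what the source reports. "The series", "measured", "known", "first", "only" and "open" are said of these compounds alone.

In an ADME assay on L929 cells (Mus musculus) for cytotoxicity, read by resazurin assay, with a stated time of 72 h (on this read-out higher numbers stand for weaker inhibition and lower numbers for stronger inhibition), compound 3 (`O=C(/C=C/c1ccc2c(c1)B(O)OC2)c1ccc(Br)cc1`) gives > 10 ug/mL, which is a limit and not a number. Compound 1 (`O=C(/C=C/c1ccc2c(c1)B(O)OC2)c1ccccn1`) gives > 10 ug/mL, also a limit. Compound 2 (`O=C(/C=C/c1ccc2c(c1)B(O)OC2)c1ccccc1`) gives > 10 ug/mL, again a limit. Going by the values given here, the series so far rests on (the limit of > 10 ug/mL in this assay, at which 3 of the 3 values shown sit).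

Compound 4 (`Nc1ccc(C(=O)/C=C/c2ccc3c(c2)B(O)OC3)cc1`) carries amino in place of bromo on an aromatic carbon, para to a large group: amino in place of bromo on an aromatic carbon.

Among the compounds with values here, the steps that bear on this are a step that the two limits leave unreadable from compound 2 to compound 3, a step that the two limits leave unreadable from compound 1 to compound 3 and a step that the two limits leave unreadable from compound 1 to compound 2. None has a readable size, so no direction carries over, and no step beyond the scatter is expected. The estimated step is a step that the limit leaves unreadable from compound 3 to compound 4. For compound 4 the expected value is 14 ug/mL, with an estimated range of 5 ug/mL to 40 ug/mL.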

Compound 4, half-maximal inhibitory concentration: > 10 ug/mL
Compound 4 gave a limit, no number; the forecaster's own chance of this, stated with the estimate: 70%; the middle value does not contradict the limit.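

No new step can be read between compound 4 and compound 1, compound 2 or compound 3, because all four values are limits: the limit of > 10 ug/mL in this assay, at which 4 of the 4 values shown sit.

On these data alone, whether the groups on the carbonyl carbon change this read-out at all stays open.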